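Methyl on the amide nitrogen: compound 3 to compound 4

The source may hold more compounds than are shown below. What is called first, only, known or untested is meant among the compounds shown, and "the series" means these compounds.

Three members of the series have a number in an assay on isolated protein (strain Sprague-Dawley) for inhibition of Amine oxidase [flavin-containing] A (Rattus norvegicus), read by spectrophotometry, with a stated time of 5 min, tested at 10 uM; a higher number here means more inhibition at the concentration tested (going by the name of the read-out), a lower number less inhibition. Compound 1 `CCOc1cc(=O)oc2cc(OCc3cccc(Cl)c3)ccc12` gives 2%. Compound 2 `COCOc1cc(=O)oc2cc(OCc3cccc(Cl)c3)ccc12` gives 23%. Compound 3 `CNC(=O)COc1cc(=O)oc2cc(OCc3cccc(Cl)c3)ccc12` gives 11%, which places compound 3 second highest of the three numbers: the step of a number 9 percentage points higher from compound 1 to compound 3 (within the scatter) lies within the scatter, whereas the step of a number 12 percentage points lower from compound 2 to compound 3 (beyond the scatter) is beyond it, and the largest movement among the measured compounds is a number 21 percentage points higher from compound 1 to compound 2 (beyond the scatter).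

Compound 4 `CN(C)C(=O)COc1cc(=O)oc2cc(OCc3cccc(Cl)c3)ccc12` is the next member. Its difference from compound 3 is methyl in place of hydrogen on an amide-type nitrogen. All three measured steps concern the group on the saturated chain carbon bound to the aromatic oxygen; none touches the amide-type nitrogen. Within the data shown here, the measured steps therefore give no direct guide to this change, and the series offers no precedent for a methyl entering at that place. Without such a precedent the working expectation in this assay is a step of no size beyond the scatter, in either direction, from compound 3 to compound 4, that is a number 1 percentage points higher from compound 3 to compound 4 (within the scatter). On that basis compound 4 is estimated at 12%, with a range from 1% to 26%, the width reflecting both the scatter of single-concentration inhibition values and the absence of a bearing step.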

Compound 4, a percentage reported as inhibition, at one concentration (the size of the read-out at that concentration, not a potency): 10%
Estimate against measurement, compound 4: 2 percentage points above; the range from low to high includes it.
By their numbers in this assay, from the lowest: compounds 1, 4 and 3 (each within the scatter of the next); then compound 2.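

The amide-type nitrogen can now be read directly in this assay: methyl in place of the amide hydrogen gives a number 1 percentage points lower from compound 3 to compound 4 (within the scatter) and so makes no difference beyond the scatter, which means that at this low level of inhibition the number does not depend on keeping the amide hydrogen. The dimethylcarbamoyl group also reads as methylcarbamoyl did against the other two members, with a number 13 percentage points lower from compound 2 to compound 4 (beyond the scatter) as a change beyond the scatter and a number 8 percentage points higher from compound 1 to compound 4 (within the scatter) as one within it, so the methoxy compound remains apart from both amides. No available evidence accounts for the absence of a step at this nitrogen.

Whether the nitrogen stays this indifferent to larger groups is open, for example an ethyl, a longer chain or a pyrrolidine ring closed through the nitrogen, and so is the behaviour of the unsubstituted carbamoyl, which has no methyl on the nitrogen at all. A carboxylic acid at the same place would show whether the amide nitrogen is needed at all, and a null step on so low a baseline says nothing about this change in a more strongly inhibiting member of the series.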